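The source may hold more compounds than are shown below. What is called first, only, known or untested is meant among the compounds shown, and "the series" means these compounds.

Measured compounds:
- Compound 1 `C#CC(O/C=C/C(=O)OC)c1ccccc1`: 26000 nM
- Compound 2 `CCC(C#CC(=O)OC)O/C=C/C(=O)OC`: 320 nM
- Compound 3 `Cc1ccc(S(=O)(=O)C#CC(O/C=C/S(=O)(=O)c2ccc(C)cc2)C(C)C)cc1`: 3800 nM

In a functional assay on HBL-100 cells (Homo sapiens) for antiproliferative activity, read by sulforhodamine B assay, with a stated time of 48 h (on this read-out lower numbers stand for stronger inhibition of growth and higher numbers for weaker inhibition of growth), compound 2 gives 320 nM, the lowest of the three numbers. Its gaps to compound 3 and compound 1 both lie beyond the usual scatter of repeat measurements.

Compound 4 `CCC(C)C(C#CC(=O)OC)O/C=C/C(=O)OC` is compound 2 with one change: ethyl in place of hydrogen on a saturated chain carbon bound to two saturated chain carbons. This turns the ethyl into a sec-butyl, with ethyl in place of hydrogen on a saturated chain carbon bound to two saturated chain carbons.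

Among the compounds with values here, no two measured compounds differ in only one place, so the data give no direct measure of a change like this. Compound 3 and compound 1 differ from compound 2 in several places, and they offer only weak guidance. A small step towards a higher number in this assay is expected, possibly one within the scatter, and the uncertainty is wide.

For compound 4, the estimated value is 600 nM, with an expected range of 150 nM to 2500 nM. This estimate means an expected 1.9-fold higher number from compound 2 to compound 4 (0.27 log units; within the scatter).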

Compound 4, concentration for 50% growth inhibition: 340 nM
The estimate for compound 4 lay 1.8-fold (0.25 log units) above the measured number; the range from low to high includes it.
By their numbers in this assay, from the lowest: compounds 2 and 4 (each within the scatter of the next); then compound 3; then compound 1.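

Within the data shown here, this pair gives the first direct reading of a single change: in this assay the two compounds show a 1.1-fold higher number from compound 2 to compound 4 (0.03 log units; within the scatter) for ethyl in place of hydrogen on a saturated chain carbon bound to two saturated chain carbons. Turning ethyl into sec-butyl at this place therefore leaves compound 2 and compound 4 indistinguishable in this assay, so on this core the site accepts the sec-butyl group with no measurable loss of growth inhibition. No measurement shown here explains this match.

This single pair cannot show whether a longer chain, an amine or a carboxylic acid at this place would also leave the number unchanged. It also cannot show whether the same change would read alike on the cores of compound 1 and compound 3.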